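Swapping a methylphenyl for a thiazole on an amide

The compounds below may be only part of what the source reports. "The series", "measured", "known", "first", "only" and "open" are said of these compounds alone.

Compound 2 `COc1ccc2nc(C)cc(OCC(=O)Nc3cccc(C)c3)c2c1` and compound 1 `COc1ccc2nc(C)cc(OC3CCN(c4ccccc4)C3=O)c2c1` share the same core. In a physicochemical assay for solubility, in phosphate buffer, measured as kinetic solubility, with a stated time of 1 h, at pH 7.4 (a higher number here means a more soluble compound, a lower number a less soluble compound), compound 2 gives 193000 nM, and compound 1 gives 215000 nM, two numbers that lie within the scatter of each other, so neither stands apart. Compound 3 `COc1ccc2nc(C)cc(OCC(=O)Nc3nc(C)c(C)s3)c2c1` differs from compound 2 in one place: 4,5-dimethyl-1,3-thiazol-2-yl in place of 3-methylphenyl on an amide-type nitrogen. Among the compounds with values here, no measured pair shows what this change does, so the expectation rests on the two numbers alone. The step from compound 2 to compound 3 is expected to be small, a 1.3-fold lower number from compound 2 to compound 3 (0.11 log units; within the scatter), perhaps downward but not clearly beyond the scatter. Compound 3 is therefore estimated at 150000 nM, within 60000 nM to 300000 nM.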

Compound 3, solubility: 31500 nM
Beside the measured number, compound 3's estimate is 4.8-fold (0.68 log units) above it, outside the stated range (below it).
By their numbers in this assay, from the lowest: compound 3; then compounds 2 and 1 (each within the scatter of the next).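

On this amide-type nitrogen, 4,5-dimethyl-1,3-thiazol-2-yl in place of 3-methylphenyl gives a 6.1-fold lower number from compound 2 to compound 3 (0.79 log units; beyond the scatter) in this assay and this step lies beyond the scatter. Within the data shown here, it is the first readable step at this position, and it shows that the two rings are not interchangeable here, even though both groups have the same heavy-atom count. Nothing measured here explains this step.

The compounds shown leave open whether the thiazole ring or its two methyl groups carry the step, as an unsubstituted 1,3-thiazol-2-yl is not among them. On these data alone, how a pyridine ring or a phenyl ring bearing an amine would read at this nitrogen also remains open.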